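This account rests on a few compounds, and the source may have more. Where it says the series, first, only, none or still open, it means among the compounds named here.

Measured in an ADME assay on microsomes from liver (Mus musculus) for metabolic stability, using NADPH, with a stated time of 60 min; a higher number here means faster removal of the compound, a lower number slower removal:
- compound 1 `O=C(Nc1ccnc(C(F)(F)F)c1)Nc1ccc(F)c(C(F)(F)F)c1` — reported as a limit of the assay, < 7 uL/min
- compound 2 `O=C(Nc1ccc(F)c(C(F)(F)F)c1)Nc1cnccn1` — 160 uL/min
- compound 3 `NC(=O)c1ccc(NC(=O)Nc2ccc(F)c(C(F)(F)F)c2)cc1` — 22 uL/min

Of the two numbers, compound 2 stands highest; the nearest, compound 3, sits a good deal lower, a gap beyond the scatter. Compound 1 gives only a limit and no number, so its distance from the others is not known (the limit of < 7 uL/min in this assay, at which 1 of the 3 values shown sits).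

Compound 4 `O=C(Nc1ccncc1)Nc1ccc(F)c(C(F)(F)F)c1` has not yet been measured in this assay. It differs from compound 2 in one place (pyridin-4-yl in place of pyrazin-2-yl on an amide-type nitrogen).

No measured pair with this same change exists in the series, so its direction is inferred only from what compound 1 and compound 2 show, and no cause for the gap between them is known from the data. Compound 4 is expected to come in lower than compound 2, with a step of about a 4.0-fold lower number from compound 2 to compound 4 (0.60 log units; beyond the scatter) in this assay. The estimate for compound 4 in this assay is 40 uL/min, with a range from 10 uL/min to 150 uL/min, the wide range reflecting that nothing measured isolates this change.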

Compound 4, intrinsic clearance in a liver preparation (reported as CLH), per the amount of preparation that the assay uses in the Mus musculus assay: 37 uL/min
The estimate for compound 4 lay 1.1-fold (0.03 log units) above the measured number; the measured number falls inside the stated range.
By their numbers in the Mus musculus assay, from the lowest: compounds 3 and 4 (each within the scatter of the next); then compound 2. At a limit, below all of these: compound 1.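

Going by these compounds alone, in the Mus musculus assay, pyridin-4-yl in place of pyrazin-2-yl on an amide-type nitrogen gives a 4.3-fold lower number from compound 2 to compound 4 (0.64 log units; beyond the scatter), the first change at this place read from a measured pair. In a physicochemical assay for lipophilicity, read by HPLC, measured as octanol-water partition, at pH 7.2 (a lower number here means a more polar compound, a higher number a more lipophilic compound), compound 2 gives 3 and compound 4 gives 3.2, with a number 0.20 log units higher from compound 2 to compound 4 (within the scatter), so this pair separates in one read-out and not in the other. In the Mus musculus assay, hydrogen in place of trifluoromethyl on an aromatic carbon gives an at least 5.2-fold higher number from compound 1 to compound 4 (0.72 log units; beyond the scatter), a step that rests on a limit held by compound 1: the limit of < 7 uL/min in the Mus musculus assay, at which 1 of the 4 values shown sits.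

The compounds shown do not tell why the pyrazin-2-yl and pyridin-4-yl compounds part in the Mus musculus assay. On these data alone, whether an amine or a methoxy group in place of trifluoromethyl would stay close to compound 1 or to compound 4 remains open.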